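The compounds below may be only part of what the source reports. "The series", "measured", "known", "first", "only" and "open" are said of these compounds alone.

Compound 1 `CC1=C(C(=O)OC2CCC2)C(c2ccco2)NC(=O)N1` and compound 2 `CC1=C(C(=O)OC2CCCC2)C(c2ccco2)NC(=O)N1` differ in one place: cyclopentyl in place of cyclobutyl on an oxygen next to a carbonyl group. In an assay on membranes from HeLa cells for displacement of a labelled ligand from adenosine receptor A3 (Homo sapiens), read by scintillation counting, with a stated time of 180 min, tested at 1 uM (on this read-out higher numbers stand for more inhibition at the one concentration tested (going by the name of the read-out) and lower numbers for less inhibition), compound 1 gives 1%, while compound 2 gives 14%, a step of a number 13 percentage points higher from compound 1 to compound 2 (beyond the scatter). Compound 3 `CC1=C(C(=O)OC2CCC2)C(c2cccs2)NC(=O)N1` has a different core than compound 1, the difference being (thiophen-2-yl in place of furan-2-yl on a saturated ring carbon). In this assay compound 3 gives 2%, a step of a number 1 percentage points higher from compound 1 to compound 3 (within the scatter) that lies within the scatter. Compound 4 `CC1=C(C(=O)OC2CCCC2)C(c2cccs2)NC(=O)N1` has not yet been measured. It differs from compound 3 by cyclopentyl in place of cyclobutyl on an oxygen next to a carbonyl group, the same change that separates compound 1 from compound 2, made at a place described in the same words. Compound 4 is therefore expected to show a step of a number 13 percentage points higher from compound 3 to compound 4 (beyond the scatter), resting on the step of a number 13 percentage points higher from compound 1 to compound 2 (beyond the scatter) and on the value of compound 3, 2%. Compound 4 is estimated at 15%, with a range from 4% to 28%.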

Compound 4, a percentage reported as inhibition, at one concentration (the size of the read-out at that concentration, not a potency): 1%
For compound 4 the middle estimate is 14 percentage points above the measured one; the whole stated range lies above it.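

Cyclopentyl in place of cyclobutyl now gives a step of a number 1 percentage points lower from compound 3 to compound 4 (within the scatter) in this assay, and thiophen-2-yl in place of furan-2-yl gives a step of a number 13 percentage points lower from compound 2 to compound 4 (beyond the scatter). The cyclopentyl change does not repeat its earlier rise on the new core, yet the two steps cannot be told apart: the same change on two cores in this assay, a number 13 percentage points higher (beyond the scatter) from compound 1 to compound 2 and a number 1 percentage points lower (within the scatter) from compound 3 to compound 4, 14 percentage points apart, within the scatter of two such steps The same holds for the thiophen-2-yl change, so these four compounds show neither that a change carries over from one core to the other nor that it fails to: the same change on two cores in this assay, a number 1 percentage points higher (within the scatter) from compound 1 to compound 3 and a number 13 percentage points lower (beyond the scatter) from compound 2 to compound 4, 14 percentage points apart, within the scatter of two such steps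

As far as these compounds go, it remains open how a cyclohexyl or benzyl group on that oxygen would read in this assay. The same is true of a phenyl group in place of furan-2-yl or thiophen-2-yl.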